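Varying the Nitrogen Substituent on a Shared Core

This account rests on a few compounds, and the source may have more. Where it says the series, first, only, none or still open, it means among the compounds named here.

Compound 1, `O=C(O)c1cc(-c2cccc(COc3ccc4c(=O)n(C5CCC5)sc4c3)c2)ccc1Cl`, gives 83% in an assay on HEK293 cells for positive allosteric modulation of metabotropic glutamate receptor 2 (Rattus norvegicus), read by thallium flux; on this read-out lower numbers stand for smaller maximal responses and higher numbers for larger maximal responses.
Compound 2, `O=C(O)c1cc(-c2cccc(COc3ccc4c(=O)n(C5CC5)sc4c3)c2)ccc1Cl`, gives 70.6%.
Compound 3, `CC(C)Cn1sc2cc(OCc3cccc(-c4ccc(Cl)c(C(=O)O)c4)c3)ccc2c1=O`, gives 76.2%.

Compound 3 stands second highest of the three numbers; the nearer gap is a number 5.6 percentage points higher from compound 2 to compound 3 (within the scatter) and the wider one is a number 6.8 percentage points lower from compound 1 to compound 3 (within the scatter). Compound 4, `O=C(O)c1cc(-c2cccc(COc3ccc4c(=O)n(CC5CC5)sc4c3)c2)ccc1Cl`, differs from compound 3 by cyclopropyl in place of isopropyl on a saturated chain carbon bound to an aromatic nitrogen. All three measured steps also exchange the group on the aromatic nitrogen, and only a number 12.4 percentage points lower from compound 1 to compound 2 (beyond the scatter) exceeded the scatter, while the two steps involving compound 3 stayed inside it. Compound 4 is therefore expected to give about 77%, between 65% and 89%. The estimated step, a number 0.8 percentage points higher from compound 3 to compound 4 (within the scatter), is expected to remain within the scatter.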

Compound 4, largest response reached (reported as percent of maximum), in percent of the reference or control that the assay uses: 38.4%
Beside the measured number, compound 4's estimate is 38.6 percentage points above it, outside the stated range (below it).
By their numbers in this assay, from the lowest: compound 4; then compounds 2, 3 and 1 (each within the scatter of the next, the first and the last beyond it).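

Among the compounds shown here, replacing isopropyl with cyclopropyl on a saturated chain carbon bound to an aromatic nitrogen gives a number 37.8 percentage points lower from compound 3 to compound 4 (beyond the scatter) in this assay, a larger step than any among the earlier compounds, so this position does not tolerate every group of the same carbon count. Cyclopropylmethyl also falls well short of the groups in the other two compounds, with a number 32.2 percentage points lower from compound 2 to compound 4 (beyond the scatter) and a number 44.6 percentage points lower from compound 1 to compound 4 (beyond the scatter) on the same read-out. No measurement here explains this drop. From the compounds shown here alone, whether cyclobutylmethyl or a longer chain such as n-pentyl would keep the response remains open.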